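The source may report more compounds than this note shows. Statements on the series, on what has been measured and on what is new or still open speak of the compounds shown alone.

Measured compounds:
Compound 1 `CCc1ccc(Nc2nccs2)cc1OCC=C(C)C`; in a functional assay on MT2 cells (Homo sapiens) for cytotoxicity (on this read-out higher numbers stand for lower toxicity in this test and lower numbers for higher toxicity in this test), compound 1 gives 31000 nM.
Compound 2 `CC(C)=CCOc1cc(Nc2nccs2)ccc1C(C)C`; in this assay compound 2 gives 31000 nM.
Compound 3 `CC(C)=CCOc1cccc(Nc2ncccn2)c1`; in this assay compound 3 gives > 100000 nM, which is a limit of the assay and not a number.

Compound 3 thus sits at the limit of > 100000 nM in this assay, at which 1 of the 3 values shown sits, and is the only one of the three that does so; compound 1 and compound 2 each carry a number. For the measured compounds named here, the single measured step, no change at the digits printed from compound 1 to compound 2 (within the scatter), concerns a saturated carbon on the aryl ring and does not touch the group on the nitrogen, so it gives no direct guide to the change examined here.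

Compound 4 `CC(C)=CCOc1cccc(Nc2nccs2)c1` is the unmeasured member. Its change from compound 3 is 1,3-thiazol-2-yl in place of pyrimidin-2-yl on a nitrogen on an aromatic ring. Going by the values given here, no measured step covers this swap. What can be said is that compound 1 and compound 2 both carry 1,3-thiazol-2-yl on that nitrogen and both return a number in this assay. Compound 3, with pyrimidin-2-yl, returns only a limit. For compound 4 the step of an at least 2.0-fold lower number from compound 3 to compound 4 (0.30 log units; that floor lies within the scatter) is therefore expected to bring the value back into the measurable range, though a limit remains a real possibility. Compound 4 is expected to give 50000 nM in this assay, within a range from 20000 nM to 150000 nM.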

Compound 4, half-maximal cytotoxic concentration: 23000 nM
The estimate for compound 4 lay 2.2-fold (0.34 log units) above the measured number; the measured number falls inside the stated range.
By their numbers in this assay, from the lowest: compounds 4, 1 and 2 (each within the scatter of the next). At a limit, above all of these: compound 3.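

For the compounds shown here, on a nitrogen on an aromatic ring, 1,3-thiazol-2-yl in place of pyrimidin-2-yl gives an at least 4.3-fold lower number from compound 3 to compound 4 (0.63 log units; beyond the scatter) in this assay, which is the first direct reading of this swap and points towards higher toxicity in this test, though its size is only a floor. That floor rests on compound 3, whose value is a limit of the assay and not a number: the limit of > 100000 nM in this assay, at which 1 of the 4 values shown sits.

With 1,3-thiazol-2-yl held on the nitrogen, the groups on the aromatic carbon can now be read as well: hydrogen in place of isopropyl gives a 1.3-fold lower number from compound 2 to compound 4 (0.13 log units; within the scatter) and hydrogen in place of ethyl gives a 1.3-fold lower number from compound 1 to compound 4 (0.13 log units; within the scatter), both within the scatter, so neither alkyl group shows a measurable effect in this test.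

As far as these compounds go, how far the true value of compound 3 lies beyond its limit stays open, so the full size of the swap is unknown. Also open, from the compounds shown here alone, is whether the reading extends to other groups on that nitrogen, such as a pyridin-2-yl or a 1,3-oxazol-2-yl ring, and whether the swap gives the same step with ethyl or isopropyl on the aromatic carbon.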